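The source may hold more compounds than are shown below. What is called first, only, known or untested is meant among the compounds shown, and "the series" means these compounds.

Working notes on the series, read in an ADME assay on L1210/0 cells (Mus musculus) for cytotoxicity, with a stated time of 48 h; on this read-out higher numbers stand for weaker inhibition and lower numbers for stronger inhibition:

- compound 1 `O=c1[nH]c(=O)n(C[C@@H]2C[C@H](O)c3ccccc32)cc1Br`: > 200000 nM (a limit of the assay, not a number)
- compound 2 `O=c1[nH]c(=O)n([C@H]2C[C@H](O)[C@@H](CO)O2)cc1/C=N/O`: 15500 nM
- compound 3 `O=C1OC(C(O)Cn2cc(F)c(=O)[nH]c2=O)C(OCc2ccccc2)=C1OCc1ccccc1`: 140000 nM

Compound 2 holds the lower of the two true numbers. Its gap to compound 3 lies beyond the scatter, and compound 3 is its nearest neighbour. The value of compound 1 gives a limit only, so it cannot be ranked exactly against the other two.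

The next compound is compound 4 `C=C(Cl)c1cn([C@H]2C[C@H](O)[C@@H](CO)O2)c(=O)[nH]c1=O`, not yet measured. It carries 1-chloroethenyl in place of a group of 3 heavy atoms, on an aromatic carbon: a group of 3 heavy atoms (2 carbon, 1 chlorine; no ring) in place of a group of 3 heavy atoms (1 carbon, 1 nitrogen, 1 oxygen; no ring), on an aromatic carbon. Within the data shown here, no measured pair sizes this replacement, so the expectation starts from compound 2 at 15500 nM. The expected step of a 1.4-fold higher number from compound 2 to compound 4 (0.15 log units; within the scatter) is not expected to go beyond the scatter, though the uncertainty is wide and leans towards higher numbers. The estimate for compound 4 is expected at 22000 nM, within a range of 5000 nM to 100000 nM.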

Compound 4, half-maximal inhibitory concentration: 1660 nM
For compound 4 the middle estimate is 13-fold (1.12 log units) above the measured one; the whole stated range lies above it.
By their numbers in this assay, from the lowest: compound 4; then compound 2; then compound 3. At a limit, above all of these: compound 1.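

In this assay, putting 1-chloroethenyl on this aromatic carbon gives a 9.3-fold lower number from compound 2 to compound 4 (0.97 log units; beyond the scatter), so this position clearly responds to a change of group. The leaving and entering groups have the same count of heavy atoms and each holds one double bond outside aromatic rings, but only the leaving group carries a hydrogen-bond donor and acceptors, so a change of this kind at constant group size is not silent here. Nothing measured in the series gives a cause for this step.

The compounds shown leave open whether the step goes with the chlorine or with the double bond of 1-chloroethenyl. A plain ethenyl or an ethyl group on this aromatic carbon would separate the two.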